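Reversed enone linker on the shared core

The compounds below may be only part of what the source reports. "The series", "measured", "known", "first", "only" and "open" are said of these compounds alone.

Going by the values given here, compound 2 `COc1ccc(/C=C/C(=O)c2cc(-c3ccc(OC)c(OC)c3)n3nc(-c4ccccc4)cc3n2)cc1` sits at the low end of the three numbers so far: in a functional assay on DU-145 cells (Homo sapiens) for antiproliferative activity, read by MTT assay, with a stated time of 24 h (a higher number here means a weaker inhibitor, a lower number a stronger inhibitor), compound 2 gives 14900 nM. Compound 3 `COc1cc(-c2cc(C(=O)/C=C/c3ccc(Cl)cc3)nc3cc(-c4ccccc4)nn23)cc(OC)c1OC` gives 19500 nM in this assay, within the scatter of compound 2. Compound 1 `COc1cc(C(=O)/C=C/c2cc(-c3cc(OC)c(OC)c(OC)c3)n3nc(-c4ccccc4)cc3n2)cc(OC)c1OC` gives 34900 nM in this assay, a higher number that lies beyond the scatter relative to compound 2.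

Compound 4 `COc1ccc(C(=O)/C=C/c2cc(-c3ccc(OC)c(OC)c3)n3nc(-c4ccccc4)cc3n2)cc1` keeps the same atoms as compound 2 but joins them differently: 2-((4-methoxyphenyl)carbonyl)ethenyl in place of (2-(4-methoxyphenyl)ethenyl)carbonyl on an aromatic carbon. The carbonyl thus moves from the ring carbon side of the enone to the 4-methoxyphenyl side. Among the compounds with values here, no measured pair in this set reports such a reversal, so its size cannot be read from the data. With the dimethoxyphenyl-bearing core of compound 2 unchanged, the expectation is a step within the scatter, or at most a small shift to a higher number, and the step from compound 2 to compound 4 is estimated at a 1.1-fold higher number from compound 2 to compound 4 (0.06 log units; within the scatter). Compound 4 is expected to give about 17000 nM in this assay, with a range from 7000 nM to 45000 nM.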

Compound 4, half-maximal inhibitory concentration: 14600 nM
Estimate against measurement, compound 4: 1.2-fold (0.07 log units) above; the range from low to high includes it.
By their numbers in this assay, from the lowest: compounds 4, 2, 3 and 1 (each within the scatter of the next, the first and the last beyond it).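

In this assay, setting 2-((4-methoxyphenyl)carbonyl)ethenyl in place of (2-(4-methoxyphenyl)ethenyl)carbonyl on this aromatic carbon gives a 1.0-fold lower number from compound 2 to compound 4 (0.01 log units; within the scatter), so with this core the direction of the enone makes no readable difference. Going by these compounds alone, this is the first comparison in the set between compounds that differ in one place, and the earlier compounds, which differ from one another in more than one place, could not show this. No measured property bears on this result, and the pair alone gives no explanation for it.

Within the data shown here, whether the reversal is equally silent with other aryl groups on the shared core remains open, since only this one pair reports it. Also open, going by these compounds, is how a saturated two-carbon chain in place of the ethenyl unit, or an amine or a carboxylic acid in place of the methoxy on the 4-methoxyphenyl ring, would read.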